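A few compounds are considered here, and "the series" means these few. Any claim that something is new, unique, unknown or untested is made for them only; others in the source may bear on it.

Compound 1 `CCCCOc1ccc(Nc2nc3nonc3nc2O)cc1` and compound 2 `Oc1nc2nonc2nc1Nc1ccc(OCC(F)(F)F)cc1` share one core and differ only in the group carried on the oxygen at the far end of the molecule. In an assay on mitochondria from L6 cells (Rattus norvegicus) for activation, with a stated time of 90 min (a higher number here means that more compound is needed for the effect, a lower number that less compound is needed), compound 1 gives 3700 nM, and compound 2 gives 42300 nM, a step of an 11-fold higher number from compound 1 to compound 2 (1.06 log units; beyond the scatter). Among the measured compounds shown here, compound 2 thus stands at the higher of the two numbers, so of these two it is the one that needs more compound.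

Compound 3 `Oc1nc2nonc2nc1Nc1ccc(OCC(F)(F)F)c(C(F)(F)F)c1` keeps everything in compound 2 and adds one group: trifluoromethyl in place of hydrogen on an aromatic carbon, placed ortho to a 2,2,2-trifluoroethoxy group. For the measured compounds named here, the single measured step concerns a change on the chain carbon, not an addition to the aromatic ring, so no step in hand speaks directly to this change. The expectation is therefore a step of a 1.1-fold lower number from compound 2 to compound 3 (0.02 log units; within the scatter), that is, no change beyond the usual scatter, with wide uncertainty. Compound 3 is estimated at 40000 nM, in the range 12000 nM to 130000 nM.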

Compound 3, half-maximal effective concentration: 4000 nM
For compound 3 the middle estimate is 10-fold (1.00 log units) above the measured one; measured number outside the range, below it.
By their numbers in this assay, from the lowest: compounds 1 and 3 (each within the scatter of the next); then compound 2.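

The aromatic ring proves to be a place where a single addition matters: in this assay, trifluoromethyl in place of hydrogen, ortho to a 2,2,2-trifluoroethoxy group, gives an 11-fold lower number from compound 2 to compound 3 (1.02 log units; beyond the scatter), so less compound is needed for the effect. Among the compounds shown here, the earlier step involved only the chain on the oxygen, so this is the first sign that a change on the ring itself can also move the number beyond the scatter. No measurement in hand bears on why the number falls.

From the compounds shown here alone, whether this drop belongs to trifluoromethyl or would also appear with a methyl group, a chlorine atom or a nitrile at the same position remains open. So does whether adding trifluoromethyl to compound 1, with its different chain, would have a similar effect.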